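This account rests on a few compounds, and the source may have more. Where it says the series, first, only, none or still open, it means among the compounds named here.

The study compares four compounds in a functional assay on the whole organism (strain CD-1) with Mus musculus as the target, with a stated time of 20 min; a higher number here means that more compound is needed for the effect, a lower number that less compound is needed. Within the data shown here, compound 2 `COCC1CN(C(C)=O)CCN1S(=O)(=O)c1ccc(F)cc1` gives 1 mg/kg in this assay, the only full number in the set. Compound 3 `COCC1CN(S(=O)(=O)c2ccc(F)cc2)CCN1C(C)=O` returns a limit of this assay, > 10 mg/kg. Compound 1 `CC(=O)OCC1CN(S(=O)(=O)c2ccc(F)cc2)CCN1C(C)=O` likewise returns only a limit, > 10 mg/kg. Compound 1 and compound 3 differ by one change, (acetyl in place of methyl on an oxygen on a saturated carbon), and the step between them, a step that the two limits leave unreadable from compound 3 to compound 1, cannot be read from two limits. Two of the three measured values sit at the same point, (the limit of > 10 mg/kg in this assay, at which 2 of the 3 values shown sit). Compound 2 and compound 3 share the same atoms joined differently; the difference between the two cores is not broken down here. Compound 4 `CC(=O)OCC1CN(C(C)=O)CCN1S(=O)(=O)c1ccc(F)cc1` is not yet measured, and it differs from compound 2 by the same change, (acetyl in place of methyl on an oxygen on a saturated carbon), at the same place. The expectation for compound 4 rests on compound 2, which gives 1 mg/kg, as the measured step offers no readable size. The step that is expected, a 3.0-fold higher number from compound 2 to compound 4 (0.48 log units; beyond the scatter), carries a real chance that only a limit is returned. Compound 4 is therefore estimated at 3 mg/kg, between 1 mg/kg and 10 mg/kg.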

Compound 4, minimum effective dose in the Mus musculus assay: 0.1 mg/kg
The estimate for compound 4 lay 30-fold (1.48 log units) above the measured number; the measured number lies below the stated range.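

In the Mus musculus assay the change from methoxymethyl to acetoxymethyl gives a 10-fold lower number from compound 2 to compound 4 (1.00 log units; beyond the scatter) on the core of compound 2, which shows a clear gain in this one pair but no general rule for the series. In a physicochemical assay for metabolic stability, read by LC-MS, in phosphate buffer, tested at 1 uM (on this read-out lower numbers stand for a shorter-lived compound and higher numbers for a longer-lived compound), compound 2 returns >= 4 h, a limit of this assay. In the physicochemical assay compound 4 returns >= 4 h, again a limit; neither this step nor the step from compound 3 to compound 1 can be read, so the compounds shown do not tell whether the change carries from one core to the other with the same size, or at all.

The compounds shown leave open whether the step in the Mus musculus assay belongs to the acetyl group itself or would also appear with a propanoyl or benzoyl group on the same oxygen. They also leave open what a free hydroxymethyl group or a longer ether chain would give at this place on either core.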